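The compounds below may be only part of what the source reports. "The series", "measured", "known", "first", "only" and "open" are said of these compounds alone.

Measured compounds:
Compound 1 `O=C(N/N=C/c1ccc([N+](=O)[O-])cc1)Nc1cc2c(Nc3ccc(F)c(Cl)c3)ncnc2cc1O[C@H]1CCOC1`: 33500 nM
Compound 2 `COc1cc2ncnc(Nc3ccc(F)c(Cl)c3)c2cc1NC(=O)N/N=C/c1ccc(F)cc1`: 36500 nM
Compound 3 `COc1cc2ncnc(Nc3ccc(F)c(Cl)c3)c2cc1NC(=O)N/N=C/c1ccc([N+](=O)[O-])cc1`: 32400 nM

These values come from a functional assay on PC-3 cells (Homo sapiens) for cytotoxicity, read by MTT assay, with a stated time of 72 h; a lower number here means a stronger inhibitor, a higher number a weaker inhibitor. Compound 3, at 32400 nM, lies within the scatter of both other compounds, so the three cannot be ranked. Compound 4 `COc1ccc(/C=N/NC(=O)Nc2cc3c(Nc4ccc(F)c(Cl)c4)ncnc3cc2OC)cc1` has not yet been measured. It differs from compound 3 by methoxy in place of nitro on an aromatic carbon.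

For the measured compounds named here, two measured steps bear on this change. The closer one is nitro in place of fluoro on an aromatic carbon, which gave a 1.1-fold lower number from compound 2 to compound 3 (0.05 log units; within the scatter). The other, methyl in place of oxolan-3-yl on an oxygen on an aromatic ring, gave a 1.0-fold lower number from compound 1 to compound 3 (0.01 log units; within the scatter). Going by the values given here, neither step exceeds the scatter, although no measured compound carries methoxy at this place. No step beyond the scatter is therefore expected in this assay, in either direction.

The estimated change is a 1.0-fold higher number from compound 3 to compound 4 (0.02 log units; within the scatter). For compound 4 the expected value is 34000 nM, with an estimated range of 18000 nM to 60000 nM.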

Compound 4, half-maximal inhibitory concentration: 16500 nM
Estimate against measurement, compound 4: 2.1-fold (0.31 log units) above, outside the stated range (below it).
By their numbers in this assay, from the lowest: compounds 4, 3, 1 and 2 (each within the scatter of the next, the first and the last beyond it).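

In this assay, for the compounds shown here, the place on the aromatic ring para to a large group responds to a substituent change for the first time: methoxy in place of fluoro gives a 2.2-fold lower number from compound 2 to compound 4 (0.34 log units; beyond the scatter), a modest step, whereas nitro in place of fluoro had stayed within the scatter. Methoxy in place of nitro gives a 2.0-fold lower number from compound 3 to compound 4 (0.29 log units; within the scatter), so the 4-methoxyphenyl compound cannot be separated from the 4-nitrophenyl compound, and only the comparison with fluoro stands out. No measurement at hand accounts for this step.

Going by these compounds, it remains open whether an amine, a carboxylic acid or a longer chain such as ethoxy at this place would go further in the same direction. Also open, on these data alone, is whether the step persists with oxolan-3-yl in place of methyl on the oxygen.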